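The source may hold more compounds than are shown below. What is called first, only, known or untested is meant among the compounds shown, and "the series" means these compounds.

Compound 1 `O=C(c1cc(C2CC2)on1)N(C1CCCCC1)C1CCCCC1` — in an assay on isolated protein for agonist activity at sphingosine 1-phosphate receptor 4 (Homo sapiens) (on this read-out lower numbers stand for an effect already at smaller amounts and higher numbers for an effect only at larger amounts of compound), compound 1 gives > 50000 nM, a limit of the assay rather than a number.

Compound 2 `CC1CCCCC1N(C(=O)c1cc(C2CC2)on1)C1CCCCCC1` — in this assay compound 2 gives > 50000 nM, likewise a limit.

Compound 1 therefore stands nowhere in particular on the numbers shown: both values sit at the same limit (the limit of > 50000 nM in this assay, at which 2 of the 2 values shown sit), and no step between measured compounds can be read from them. Compound 3 `CC(C)c1cc(C(=O)N(C2CCCCC2)C2CCCCC2)no1` differs from compound 1 by isopropyl in place of cyclopropyl on an aromatic carbon. Within the data shown here, with no measured step to draw on, the account expects in this assay no step beyond the scatter, as a step that the limit leaves unreadable from compound 1 to compound 3 is meant to say. Compound 3 is accordingly expected at 70000 nM, in the range from 20000 nM to 300000 nM, and most probably the assay will again report only a limit for compound 3 rather than a number.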

Compound 3, half-maximal effective concentration: > 50000 nM
Compound 3: no number, only a limit (the forecaster's own chance of this, stated with the estimate: 85%); the middle value does not contradict the limit.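

In this assay compound 3 gives > 50000 nM as a limit and not a number. Among these compounds, no step between compound 1 and compound 3 can therefore be read: the limit of > 50000 nM in this assay, at which 3 of the 3 values shown sit. The compounds shown leave open what change to the shared core, if any, would give a measured number in this assay here.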